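The source may hold more compounds than are shown below. What is called first, only, known or untested is meant among the compounds shown, and "the series" means these compounds.

Working notes on the series.

Compound 1 `CCN(CC)S(=O)(=O)c1ccc(S(=O)(=O)N2CCC[C@@H](C(=O)N3CCC(OC)CC3)C2)cc1` gives 1420 nM in a functional assay on BXPC-3 cells (Homo sapiens) for inhibition, read by MTT assay, with a stated time of 7 days; on this read-out higher numbers stand for weaker inhibition and lower numbers for stronger inhibition. Compound 2 `CCN(CC)S(=O)(=O)c1ccc(S(=O)(=O)N2CCC[C@@H](C(=O)NC3CCOCC3)C2)cc1` gives 8570 nM, and compound 3 `CCN(CC)S(=O)(=O)c1ccc(S(=O)(=O)N2CCC[C@@H](C(=O)N[C@@H]3CCOC3)C2)cc1` gives 2270 nM. Among the three numbers compound 3 stands second highest: its nearest neighbour is compound 1, with a 1.6-fold higher number from compound 1 to compound 3 (0.20 log units; within the scatter), and the widest gap is to compound 2, with a 3.8-fold lower number from compound 2 to compound 3 (0.58 log units; beyond the scatter). The remaining measured step, a 6.0-fold higher number from compound 1 to compound 2 (0.78 log units; beyond the scatter), separates the two amides built on a secondary nitrogen from the tertiary piperidine amide of compound 1.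

Compound 4 `CCN(CC)S(=O)(=O)c1ccc(S(=O)(=O)N2CCC[C@@H](C(=O)N3CCC(C(F)F)CC3)C2)cc1` differs from compound 3 by 4-(difluoromethyl)piperidin-1-yl in place of (oxolan-3-yl)amino on a carbonyl carbon. The step that bears most directly on it is a 1.6-fold higher number from compound 1 to compound 3 (0.20 log units; within the scatter), since compound 4 returns to a piperidin-1-yl amide on the carbonyl carbon, as in compound 1. Going by the values given here, that step lay within the scatter, and no measured pair shows what the difluoromethyl group on the piperidine contributes in place of methoxy. The expectation is therefore a small step, a 1.5-fold lower number from compound 3 to compound 4 (0.18 log units; within the scatter), toward a number close to that of compound 1. Compound 4 is estimated at 1500 nM, in the range 500 nM to 4500 nM.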

Compound 4, half-maximal inhibitory concentration: 450 nM
Compound 4: the middle estimate sits 3.3-fold (0.52 log units) above what was measured, outside the stated range (below it).
By their numbers in this assay, from the lowest: compound 4; then compounds 1 and 3 (each within the scatter of the next); then compound 2.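

Going by these compounds alone, replacing methoxy with difluoromethyl on a saturated ring carbon of the piperidine gives a 3.2-fold lower number from compound 1 to compound 4 (0.50 log units; beyond the scatter), so the group carried on that ring changes the number in this assay, which the earlier compounds could not show. Compound 1 and compound 3 lay within the scatter of each other, whereas the 4-(difluoromethyl)piperidin-1-yl amide separates clearly from the secondary amides, with a 5.0-fold lower number from compound 3 to compound 4 (0.70 log units; beyond the scatter) and a 19-fold lower number from compound 2 to compound 4 (1.28 log units; beyond the scatter). No measurement at hand offers an explanation for these steps.

From the compounds shown here alone, it remains open whether a methyl, a trifluoromethyl or an unsubstituted piperidine would stand with compound 4 or with compound 1. Also open, going by these compounds, is whether the step from methoxy to difluoromethyl would hold on the core with the opposite configuration at its stereocentre.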